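Styryl pyranones and lactones: a third methoxy on the ring

The source may report more compounds than this note shows. Statements on the series, on what has been measured and on what is new or still open speak of the compounds shown alone.

Values in a functional assay on NCI-H460 cells (Homo sapiens) for inhibition, read by sulforhodamine B assay, with a stated time of 48 h; a higher number here means a weaker inhibitor of growth, a lower number a stronger inhibitor of growth:
compound 1 `O=C1C=COC(/C=C/c2ccccc2)C1`: 82.4 uM
compound 2 `COc1ccc(/C=C/C2CC(=O)C=CO2)cc1`: 149 uM
compound 3 `COc1cc(/C=C/C2CC=CC(=O)O2)cc(OC)c1`: 9 uM

Compound 1 and compound 2 share a core and differ by methoxy in place of hydrogen on an aromatic carbon. That step, a 1.8-fold higher number from compound 1 to compound 2 (0.26 log units; within the scatter), lies within the scatter, so the two values are read as equivalent. Compound 3 stands on a different core; the difference between the two cores is not broken down here. Compound 3 gives the lowest number of the three in this assay, and its steps to compound 1 and compound 2 are both beyond the scatter.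

Compound 4 `COc1cc(/C=C/C2CC=CC(=O)O2)cc(OC)c1OC` is not yet measured. It differs from compound 3 by methoxy in place of hydrogen on an aromatic carbon. This is the same kind of change as that from compound 1 to compound 2, not the same: in compound 4 the entering methoxy sits ortho to two methoxy groups, whereas in compound 2 it sits only para to a group of 9 heavy atoms. Because a 1.8-fold higher number from compound 1 to compound 2 (0.26 log units; within the scatter) was within the scatter, the expected step of a 1.3-fold higher number from compound 3 to compound 4 (0.12 log units; within the scatter) is likewise small. Compound 4 is estimated at 12 uM in this assay, expected within 4 uM to 36 uM.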

Compound 4, concentration for growth inhibition (reported as GI): 28.8 uM
For compound 4 the middle estimate is 2.4-fold (0.38 log units) below the measured one; low and high end bracket the measured number.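

In this assay, methoxy in place of hydrogen on an aromatic carbon gives a 3.2-fold higher number from compound 3 to compound 4 (0.51 log units; beyond the scatter) and so weakens growth inhibition modestly on the core of compound 3. This does not show that the change behaves identically on every core: the series offers one pair per core, and in compound 4 the entering methoxy is ortho to two methoxy groups, a surrounding absent from the pair on the core of compound 1. The two steps nevertheless cannot be told apart in size, so the change carries across these two cores without a measurable difference: the same change on two cores in this assay, a 1.8-fold higher number (0.26 log units; within the scatter) from compound 1 to compound 2 and a 3.2-fold higher number (0.51 log units; beyond the scatter) from compound 3 to compound 4, 1.8-fold (0.25 log units) apart, within the scatter of two such steps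

No pair shown differs in the core alone, so the contribution of the core itself remains unresolved. Also open, on these data alone, is whether the same ring position would tolerate a hydroxyl, an amine or a carboxylic acid in place of the methoxy, or a longer alkoxy chain.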